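Flipping a Single Stereocentre on the Shared Core

This account rests on a few compounds, and the source may have more. Where it says the series, first, only, none or still open, it means among the compounds named here.

Compound 1, `COC(=O)[C@@H]1c2cc(/C=C/C(=O)NCCCCNC(=N)N)ccc2O[C@H]1c1ccc(O)cc1`: 560000 nM in an assay on isolated protein (Salivary gland) for displacement of a labelled ligand from Alpha-1A adrenergic receptor (Rattus norvegicus); on this read-out higher numbers stand for weaker inhibition and lower numbers for stronger inhibition.
Compound 2, `N=C(N)NCCCCNC(=O)/C=C/c1ccc2c(c1)[C@@H](C(=O)NCCCCNC(=N)N)[C@H](c1ccc(O)cc1)O2`: 290000 nM in this assay.
Compound 3, `COC(=O)[C@H]1c2cc(/C=C/C(=O)NCCCCNC(=N)N)ccc2O[C@@H]1c1ccc(O)cc1`: 2160000 nM in this assay.

Compound 2 gives the lowest of the three numbers in this assay. Its nearest neighbour is compound 1; that step, a 1.9-fold lower number from compound 1 to compound 2 (0.29 log units; within the scatter), is within the scatter, so the two cannot be told apart. Compound 3 lies furthest away. For the measured compounds named here, the only step that separates two compounds beyond the scatter is the one from compound 1 to compound 3, a 3.9-fold higher number from compound 1 to compound 3 (0.59 log units; beyond the scatter), and it rests on configuration alone: the fact that one of compounds 1 and 3 is drawn with a defined configuration and the other without, at the place where they differ.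

Compound 4, `N=C(N)NCCCCNC(=O)/C=C/c1ccc2c(c1)[C@@H](C(=O)NCCCCNC(=N)N)[C@@H](c1ccc(O)cc1)O2`, keeps all atoms and bonds of compound 2 and differs only by the two compounds have the same atoms and bonds; at least one stereo element is drawn with a configuration in one of them and without one in the other: 1 of 5 stereo elements differ; a stereocentre at a saturated ring carbon is drawn R in compound 2 and S in compound 4. Going by the values given here, the step from compound 1 to compound 3 is the one measured change of the same kind, though there two centres were redrawn rather than one, and it gave a modest rise. Compound 4 is therefore expected to give a somewhat higher number than compound 2, with a step of a 2.1-fold higher number from compound 2 to compound 4 (0.32 log units; beyond the scatter) in this assay. The estimate for compound 4 in this assay is 600000 nM, expected to fall between 200000 nM and 1800000 nM.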

Compound 4, half-maximal inhibitory concentration: 2440000 nM
Compound 4: the middle estimate sits 4.1-fold (0.61 log units) below what was measured, outside the stated range (above it).
By their numbers in this assay, from the lowest: compounds 2 and 1 (each within the scatter of the next); then compounds 3 and 4 (each within the scatter of the next).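

In this assay, a single stereocentre at a saturated ring carbon, drawn R in compound 2 and S in compound 4, is enough on its own to carry the number beyond the scatter, with an 8.4-fold higher number from compound 2 to compound 4 (0.92 log units; beyond the scatter). The earlier step of this kind, a 3.9-fold higher number from compound 1 to compound 3 (0.59 log units; beyond the scatter), redrew two centres at once and so could not show whether one centre alone would suffice; it also belonged to the methyl ester, whereas this step holds with the larger group on the carbonyl carbon that compound 2 and compound 4 share. With atoms and bonds identical in the pair, the step rests on configuration alone: the fact that one of compounds 2 and 4 is drawn with a defined configuration and the other without, at the place where they differ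

Still open, from the compounds shown here alone, is whether the other centre redrawn between compound 1 and compound 3, changed alone, would also move the number beyond the scatter, and whether the centre changed here does so on the methyl ester. Equally open, going by these compounds, is whether the same redrawing gives a comparable step with a carboxylic acid or a primary amide on that carbonyl carbon.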